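The source may hold more compounds than are shown below. What is called first, only, known or untested is meant among the compounds shown, and "the series" means these compounds.

Measured so far:
compound 1 `COc1cc(N2C(N)=C(C#N)C(c3ccc(OC)c4ccccc34)C3=C2CC(C)(C)CC3=O)cc(OC)c1OC` — 10%
compound 2 `COc1cc(N2C(N)=C(C#N)C(c3ccc(Cl)cc3Cl)C3=C2CC(C)(C)CC3=O)cc(OC)c1OC` — 20%

In a functional assay on Ehrlich cells (Mus musculus) for cytotoxicity, tested at 10 ug/mL (a lower number here means a weaker effect, a higher number a stronger effect of the compound at the concentration tested), compound 2 gives 20%. Compound 1 gives 10%. The two stand within the scatter of each other, the step being a number 10 percentage points higher from compound 1 to compound 2 (within the scatter). Compound 3 `COc1cc(N2C(N)=C(C#N)C(c3cccs3)C3=C2CC(C)(C)CC3=O)cc(OC)c1OC` differs from compound 2 by thiophen-2-yl in place of 2,4-dichlorophenyl on a saturated ring carbon. Within the data shown here, the only measured step at that saturated ring carbon, a number 10 percentage points higher from compound 1 to compound 2 (within the scatter), stayed within the scatter, so in this assay no step beyond the scatter is expected; the estimated step is a number 5 percentage points lower from compound 2 to compound 3 (within the scatter). For compound 3 the expected value is 15%, with a range from 5% to 30%.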

Compound 3, a percentage reported as activity, at one concentration (the size of the read-out at that concentration, not a potency): 5%
For compound 3 the middle estimate is 10 percentage points above the measured one; measured number inside the range.
By their numbers in this assay, from the lowest: compounds 3, 1 and 2 (each within the scatter of the next, the first and the last beyond it).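

In this assay this saturated ring carbon now gives a step beyond the scatter, modest in size: a number 15 percentage points lower from compound 2 to compound 3 (beyond the scatter) when thiophen-2-yl replaces 2,4-dichlorophenyl. By contrast, a number 5 percentage points lower from compound 1 to compound 3 (within the scatter) stays within the scatter, so thiophen-2-yl and 4-methoxynaphthalen-1-yl are not separated here, and only the two ends of the series stand apart. No measured evidence bears on the origin of this step.

Still open, as far as these compounds go, is what a pyridin-3-yl or 4-carboxyphenyl group at this carbon would give, and whether any group here can carry the read-out well past the level of compound 2.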